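The compounds below may be only part of what the source reports. "The series", "measured", "known", "first", "only" and "open" are said of these compounds alone.

Compound 1: `Oc1nnc(-c2cccnc2)c2ccccc12` — 26%
Compound 2: `CCCCCCCCn1nc(-c2cccnc2)c2ccccc2c1=O` — 99%

Compound 2, `CCCCCCCCn1nc(-c2cccnc2)c2ccccc2c1=O`, gives 99% in an assay on isolated protein (Oryctolagus cuniculus) with Thromboxane-A synthase (Homo sapiens) as the target, tested at 1 uM (a higher number here means more inhibition at the concentration tested (going by the name of the read-out), a lower number less inhibition), the highest of the two numbers measured. The nearest measured compound is compound 1, `Oc1nnc(-c2cccnc2)c2ccccc12`, which in this assay gives 26%; the two values lie far apart, well beyond the scatter of repeated measurements. The next compound, compound 3, `O=c1c2ccccc2c(-c2cccnc2)nn1Cc1ccccc1`, has not yet been tested in this assay. It differs from compound 2 in one place: phenyl in place of heptyl on a saturated chain carbon bound to an aromatic nitrogen. Cut one bond further out, the same difference reads octyl to benzyl, so a group on the aromatic nitrogen is kept in compound 3, while compound 1 has none there.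

Among the measured compounds shown here, no step between compound 2 and compound 3 has been measured, so what follows is an expectation only. Compound 3 is expected to keep a high number in this assay because compound 2, which also carries a group on that nitrogen, gives 99%. The expected step of a number 14 percentage points lower from compound 2 to compound 3 (beyond the scatter) is a modest fall, at about the edge of the scatter. Compound 3 is estimated at 85% in this assay, within 55% to 99%.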

Compound 3, a percentage reported as inhibition, at one concentration (the size of the read-out at that concentration, not a potency): 97%
Estimate against measurement, compound 3: 12 percentage points below, within the range that was stated.
By their numbers in this assay, from the lowest: compound 1; then compounds 3 and 2 (each within the scatter of the next).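

Phenyl in place of heptyl on a saturated chain carbon bound to an aromatic nitrogen gives a number 2 percentage points lower from compound 2 to compound 3 (within the scatter) in this assay and so leaves compound 2 and compound 3 indistinguishable in this measurement. At this place, then, the read-out holds up with an open chain and equally with a group carrying a six-membered aromatic ring of carbon only, so the high number of compound 2 does not depend on the heptyl part of its octyl group. Both numbers lie close to the top of the percentage scale at the single concentration tested, so they cannot rank the two compounds by potency, and no measurement at hand bears on why the change makes so little difference.

Still open, going by these compounds, is whether a much shorter group such as methyl would hold the number in this assay as well as octyl and benzyl do. On these data alone, it is equally open what an amine or a carboxylic acid at the end of the chain would do, or a chlorine on the phenyl of the benzyl group.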